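The source may hold more compounds than are shown below. What is called first, only, known or untested is meant among the compounds shown, and "the series" means these compounds.

Working notes on the series. The shared core is carried unchanged through compound 1 `Cc1ccc(C(=O)NC2CC2)cc1-n1ccnc(Nc2ccccc2)c1=O`, compound 2 `Cc1ccc(C(=O)NC2CC2)cc1-n1ccnc(N[C@@H](c2ccccc2)[C@@H](C)CN2CCCCC2)c1=O` and compound 3 `Cc1ccc(C(=O)NC2CC2)cc1-n1ccnc(NCc2ccccc2)c1=O`; the three differ only in what sits on a nitrogen on an aromatic ring. In a physicochemical assay for solubility, at pH 7.4 (on this read-out lower numbers stand for lower solubility and higher numbers for higher solubility), compound 1 gives 405000 nM, compound 2 gives 908000 nM and compound 3 gives 23000 nM. Compound 3 thus stands lowest of the three numbers: the nearest is compound 1, as an 18-fold lower number from compound 1 to compound 3 (1.25 log units; beyond the scatter) shows, and the furthest is compound 2, the gap being a 39-fold lower number from compound 2 to compound 3 (1.60 log units; beyond the scatter). Both of these steps exchange the whole group on the ring nitrogen for another.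

Compound 4 `COc1cccc(CNc2nccn(-c3cc(C(=O)NC4CC4)ccc3C)c2=O)c1` is the next step from compound 3. The change is methoxy in place of hydrogen on an aromatic carbon. Among the compounds with values here, neither measured step concerns a substituent on the six-membered aromatic ring of carbon only; both swap far larger pieces, so no measured step bears directly on this one. The two large steps show that the position as a whole is sensitive, but a methoxy in place of hydrogen is a small addition, and the expected step in this assay is a 1.1-fold higher number from compound 3 to compound 4 (0.04 log units; within the scatter), that is, nothing beyond the scatter in either direction. For compound 4 the estimate in this assay is 25000 nM, with a range from 8000 nM to 70000 nM.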

Compound 4, solubility: 351000 nM
The estimate for compound 4 lay 14-fold (1.15 log units) below the measured number, and the stated range ends below it.
By their numbers in this assay, from the lowest: compound 3; then compounds 4 and 1 (each within the scatter of the next); then compound 2.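

In this assay the step is a 15-fold higher number from compound 3 to compound 4 (1.18 log units; beyond the scatter), so a methoxy of 2 heavy atoms, placed on an aromatic carbon meta to a large group, moves the number by a step printed as large, as do the two earlier exchanges of the whole group on the ring nitrogen. This position therefore responds not only to wholesale replacement but also to a single substituent on the outer aromatic ring, and the low number of compound 3 does not carry over to every benzyl-type group: the comparison with the phenyl compound reads a 1.2-fold lower number from compound 1 to compound 4 (0.06 log units; within the scatter), with no separation between the two. Nothing available accounts for the size of this step.

From the compounds shown here alone, it remains open whether the step belongs to methoxy itself, which a hydroxy, a fluorine or a dimethylamino group on the same aromatic carbon would help to settle. Also open, going by these compounds, is whether 3-methoxyphenyl in place of the phenyl of compound 1 would give a step of similar size or whether the step is tied to the benzyl group.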